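Trimming the polyamine tail of a chalcone conjugate

A few compounds are considered here, and "the series" means these few. Any claim that something is new, unique, unknown or untested is made for them only; others in the source may bear on it.

Compound 1 `COc1ccc(/C=C/C(=O)c2cc(OC)c(OC)c(OC)c2)cc1OCCCC(=O)NCCCCN(CCCN)CCCCN` in a functional assay on PC-3 cells (Homo sapiens) for antiproliferative activity, read by MTT assay, with a stated time of 48 h; a lower number here means a stronger inhibitor, a higher number a weaker inhibitor: 60600 nM
Compound 2 `COc1ccc(/C=C/C(=O)c2cc(OC)c(OC)c(OC)c2)cc1OCCCC(=O)NCCCCN(CCCN)CCCCNCCCN` in this assay: 48100 nM
Compound 3 `COc1cc(C(=O)/C=C/c2ccc(OCCCC(=O)NCCCNCCCCNCCN)cc2)cc(OC)c1OC` in this assay: 34000 nM

Among the three measured compounds, compound 2 gives the second highest number in this assay. Its nearest neighbour is compound 1, whose value sits within the scatter of that of compound 2; compound 3 lies furthest away, but its value and that of compound 2 also fall within the scatter of each other, so the three measured values cannot be ordered.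

Compound 4 `COc1ccc(/C=C/C(=O)c2cc(OC)c(OC)c(OC)c2)cc1OCCCC(=O)NCCCCNCCCN` is reached from compound 2 by a single change: hydrogen in place of 4-((3-aminopropyl)amino)butyl on an amine nitrogen. Among the measured compounds shown here, only one measured step bears on this kind of change at a polyamine nitrogen, the step of a 1.3-fold lower number from compound 1 to compound 2 (0.10 log units; within the scatter), which went in the opposite sense, adding a 3-aminopropyl arm, and stayed within the scatter. Removing a longer arm from compound 2 is therefore expected to leave the number in this assay essentially where it is, with no step beyond the scatter in either direction.

On that basis the estimated step is a 1.1-fold higher number from compound 2 to compound 4 (0.06 log units; within the scatter), and compound 4 is expected to give about 55000 nM in this assay, with a range from 25000 nM to 120000 nM.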

Compound 4, half-maximal inhibitory concentration: 51000 nM
Compound 4: middle estimate off by 1.1-fold (0.03 log units), on the high side; the range from low to high includes it.
By their numbers in this assay, from the lowest: compounds 3, 2, 4 and 1 (each within the scatter of the next).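

Hydrogen in place of 4-((3-aminopropyl)amino)butyl on the amine nitrogen amounts to a 1.1-fold higher number from compound 2 to compound 4 (0.03 log units; within the scatter) in this assay, and hydrogen in place of 4-aminobutyl at the same nitrogen amounts to a 1.2-fold lower number from compound 1 to compound 4 (0.07 log units; within the scatter). The earlier step compared only two arms that both carried a 4-aminobutyl stretch, whereas these steps take the arm away altogether, including a group of 9 heavy atoms, and the number still stays within the scatter, so hydrogen, 4-aminobutyl and 4-((3-aminopropyl)amino)butyl on this nitrogen cannot be told apart in these compounds. No measurement offered here accounts for this lack of separation.

The compounds shown leave open whether any other group on this nitrogen, such as an acetyl or a benzyl group, would give a step beyond the scatter. They also leave open what the remaining tail contributes, for instance whether a carboxylic acid in place of the polyamine chain, or a shorter chain ending in a single primary amine, would give a number different from those of compound 2 and compound 4.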